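The compounds below may be only part of what the source reports. "The series", "measured", "known", "first", "only" and "open" are said of these compounds alone.

Measured compounds:
- Compound 1, `C/C(=N\NC(=O)c1cccc(S(=O)(=O)N2CCOCC2)c1)c1cccc(N)c1`: in a functional assay on MCF7 cells (Homo sapiens) for antiproliferative activity, read by MTT assay, with a stated time of 72 h (a higher number here means a weaker inhibitor, a lower number a stronger inhibitor), compound 1 gives > 100000 nM, which is a limit of the assay.
- Compound 2, `C/C(=N\NC(=O)c1cccc(S(=O)(=O)N2CCOCC2)c1)c1ccc(F)cc1`: in this assay compound 2 gives > 100000 nM, again a limit of the assay and not a number.

Compound 2 therefore stands nowhere readable on the scale: both values shown sit at the same limit, (the limit of > 100000 nM in this assay, at which 2 of the 2 values shown sit). Among the compounds with values here, the one measured step, a step that the two limits leave unreadable from compound 1 to compound 2, is unreadable for the same reason, so the series so far carries no information on how a change at the carbon with a double bond to nitrogen moves the read-out.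

Compound 3, `C/C(=N\NC(=O)c1cccc(S(=O)(=O)N2CCOCC2)c1)c1ccccc1O`, differs from compound 2 by 2-hydroxyphenyl in place of 4-fluorophenyl on a carbon with a double bond to nitrogen. Within the data shown here, the only step that bears on this position is the unreadable one from compound 1 to compound 2, so no direction or size can be drawn from it for this assay; the expectation is that compound 3 also returns a limit rather than a number, which means a step of a number no higher from compound 2 to compound 3 (the limit leaves the size open). The estimate for compound 3 is 100000 nM, with a range from 30000 nM to 300000 nM.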

Compound 3, half-maximal inhibitory concentration: 5400 nM
The estimate for compound 3 lay 19-fold (1.27 log units) above the measured number; measured number outside the range, below it.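

In this assay, the group on the carbon with a double bond to nitrogen can move the read-out off the limit: 2-hydroxyphenyl in place of 4-fluorophenyl gives an at least 18-fold lower number from compound 2 to compound 3 (1.26 log units; beyond the scatter), and 2-hydroxyphenyl in place of 3-aminophenyl gives an at least 18-fold lower number from compound 1 to compound 3 (1.26 log units; beyond the scatter). Within the data shown here, compound 3 is therefore the first compound with a number rather than a limit, which shows that a change at this one position, with the rest of the structure held constant, is enough to produce a measurable value. Both steps remain open-ended on one side, since the values for compound 1 and compound 2 are limits of the assay and not numbers: the limit of > 100000 nM in this assay, at which 2 of the 3 values shown sit.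

The compounds shown leave open whether the hydroxyl group itself or its place on the phenyl ring accounts for the step, as 2-hydroxyphenyl is the only hydroxyl-bearing group here. They also leave open how the read-out would respond if a methoxy group, a carboxylic acid or an unsubstituted phenyl ring stood at this position.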